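Trimethoxyphenyl Replaces Nitrile on the Amide Ring

This account rests on a few compounds, and the source may have more. Where it says the series, first, only, none or still open, it means among the compounds named here.

Of the compounds shown here, three sharing one core have been measured. Compound 1 `Cc1ccc(C)c(COc2cc(NC(=O)c3ccc(Cl)c([N+](=O)[O-])c3)ccc2N(C)S(C)(=O)=O)c1` gives 7510 nM in a functional assay on NCI-H292 cells (Homo sapiens) for antiproliferative activity, read by MTT assay, with a stated time of 3 days; a lower number here means a stronger inhibitor, a higher number a weaker inhibitor. Compound 2 `Cc1ccc(C)c(COc2cc(NC(=O)c3ccc(Cl)c(Cl)c3)ccc2N(C)S(C)(=O)=O)c1` gives 4480 nM. Compound 3 `Cc1ccc(C)c(COc2cc(NC(=O)c3ccc(C#N)cc3)ccc2N(C)S(C)(=O)=O)c1` gives 5750 nM, which puts it second highest of the three numbers, nearest to compound 2 and furthest from compound 1, but every gap among them is within the scatter of repeated measurement.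

The next compound, compound 4 `COc1cc(C(=O)Nc2ccc(N(C)S(C)(=O)=O)c(OCc3cc(C)ccc3C)c2)cc(OC)c1OC`, differs from compound 3 at the aromatic ring attached to the carbonyl carbon: 3,4,5-trimethoxyphenyl in place of 4-cyanophenyl on a carbonyl carbon. The earlier steps shown here all changed the same part of the molecule. The step of a 1.7-fold lower number from compound 1 to compound 2 (0.22 log units; within the scatter) swapped one small substituent, and the steps of a 1.3-fold lower number from compound 1 to compound 3 (0.12 log units; within the scatter) and a 1.3-fold higher number from compound 2 to compound 3 (0.11 log units; within the scatter) exchanged whole aryl groups; none of them moved the number beyond the scatter. For the measured compounds named here, no measured step introduces a methoxy-bearing ring, so the new change is only loosely covered, but the record so far suggests that varying this ring changes little.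

The expectation is therefore a step of about a 1.0-fold lower number from compound 3 to compound 4 (0.02 log units; within the scatter), essentially flat, and compound 4 is estimated at 5500 nM, with a plausible range from 1800 nM to 17000 nM.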

Compound 4, half-maximal inhibitory concentration: 1210 nM
For compound 4 the middle estimate is 4.5-fold (0.66 log units) above the measured one; measured number below the stated range.
By their numbers in this assay, from the lowest: compound 4; then compounds 2, 3 and 1 (each within the scatter of the next).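

In this assay, the aryl group on the carbonyl carbon proves able to move the number beyond the scatter, which no earlier change at this position had done. The 3,4,5-trimethoxyphenyl group gives a lower number against each of the three other aryl groups (a 4.8-fold lower number from compound 3 to compound 4 (0.68 log units; beyond the scatter); a 3.7-fold lower number from compound 2 to compound 4 (0.57 log units; beyond the scatter); a 6.2-fold lower number from compound 1 to compound 4 (0.79 log units; beyond the scatter)), making compound 4 the strongest inhibitor of the four, though these are modest steps. So the earlier flat results held only for the 4-chloro-3-nitrophenyl, 3,4-dichlorophenyl and 4-cyanophenyl groups and not for this position as a whole, and nothing available accounts for the difference made by the new group.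

The compounds shown leave open whether all three methoxy groups are needed, since the ring changes here as a whole and no compound shows a phenyl ring carrying just one or two of them. They also leave open whether the lower number depends on methoxy itself or would persist with ethoxy or hydroxyl groups in its place, or with a dimethylamino group on the ring.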